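Swapping an aryl for a cyclohexenyl on the shared core

The source may report more compounds than this note shows. Statements on the series, on what has been measured and on what is new or still open speak of the compounds shown alone.

Compound 1 `C=CS(=O)(=O)N1CCN(c2ncnc3sc(-c4ccc(C(F)(F)F)cc4)cc23)CC1` is the starting point. Among the measured compounds shown here, in a functional assay on MDA-MB-231 cells (Homo sapiens) for antiproliferative activity, read by MTT assay, with a stated time of 48 h (on this read-out lower numbers stand for stronger inhibition and higher numbers for weaker inhibition), compound 1 gives 6410 nM, the lowest of the three numbers measured so far. Compound 2 `C=CS(=O)(=O)N1CCN(c2ncnc3sc(-c4ccc(OC)cc4)cc23)CC1` gives 29900 nM in this assay, and compound 3 `C=CS(=O)(=O)N1CCN(c2ncnc3sc(-c4ccc(F)nc4)cc23)CC1` gives 16000 nM.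

Compound 4 `C=CS(=O)(=O)N1CCN(c2ncnc3sc(C4=CCCCC4)cc23)CC1` has not yet been measured. It differs from compound 1 at the group attached to the five-membered ring of the shared core: cyclohex-1-en-1-yl in place of 4-(trifluoromethyl)phenyl on an aromatic carbon

Two measured steps start from compound 1 and change that same group. There is a 4.7-fold higher number from compound 1 to compound 2 (0.67 log units; beyond the scatter), and a 2.5-fold higher number from compound 1 to compound 3 (0.40 log units; beyond the scatter). Both replacements of the 4-(trifluoromethyl)phenyl gave higher numbers, so a weaker result. The move to a cyclohex-1-en-1-yl is a larger change than either, since the aromatic ring itself is lost. A step to a higher number is therefore expected for compound 4, of roughly the size seen in those two steps, estimated as a 3.1-fold higher number from compound 1 to compound 4 (0.49 log units; beyond the scatter). Compound 4 is expected to give about 20000 nM in this assay, within a range from 7000 nM to 60000 nM.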

Compound 4, half-maximal inhibitory concentration: > 50000 nM
Compound 4: a limit, no number; the forecaster's own chance of this, stated with the estimate: 15%; middle value at least 2.5-fold (0.39 log units) away from the limit.
By their numbers in this assay, from the lowest: compound 1; then compounds 3 and 2 (each within the scatter of the next). At a limit, above all of these: compound 4.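

For compound 4 the reading in this assay is a limit of the assay and not a number: the limit of > 50000 nM in this assay, at which 1 of the 4 values shown sits. At this position, next to the ring sulfur, the three aromatic rings all gave numbers, whereas the non-aromatic cyclohex-1-en-1-yl gives an at least 7.8-fold higher number from compound 1 to compound 4 (0.89 log units; beyond the scatter) and an at least 3.1-fold higher number from compound 3 to compound 4 (0.49 log units; beyond the scatter), so this change costs activity against both the 4-(trifluoromethyl)phenyl and the 6-fluoropyridin-3-yl. The third comparison is less firm, at an at least 1.6-fold higher number from compound 2 to compound 4 (0.22 log units; that floor lies within the scatter), so the cyclohex-1-en-1-yl cannot be placed apart from the 4-methoxyphenyl.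

The compounds shown leave open how a plain phenyl or a saturated cyclohexyl would read here, so losing the aromatic ring cannot be separated from losing the ring's substituent. The limit also leaves the full size of each step open.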